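The compounds below may be only part of what the source reports. "The series", "measured", "known", "first", "only" and "open" are said of these compounds alone.

Compound 1 `Cn1c(-c2ccc(NC(=O)CN3CCN(c4ccccc4)CC3)cc2)nc2cc(C(F)(F)F)ccc21` gives 1400 nM in an ADME assay on MDBK cells (Bos taurus) for cytotoxicity, read by MTT assay, with a stated time of 96 h (on this read-out higher numbers stand for lower toxicity in this test and lower numbers for higher toxicity in this test), the lower of the two numbers in hand. Among the measured compounds shown here, compound 2 `Cn1c(-c2ccc(NC(=O)CN3CCCCC3)cc2)nc2cc(C(F)(F)F)ccc21` gives 100000 nM in this assay; the only measured step, a 71-fold higher number from compound 1 to compound 2 (1.85 log units; beyond the scatter), concerns the chain on the amide side. Compound 3 `O=C(CN1CCN(c2ccccc2)CC1)Nc1ccc(-c2nc3cc(C(F)(F)F)ccc3[nH]2)cc1` differs from compound 1 in hydrogen in place of methyl on an aromatic nitrogen, a change on the shared core. For the measured compounds named here, no measured step touches that position; nothing in hand shows how this assay answers to it. The expected step is within the usual scatter, no change at the digits printed from compound 1 to compound 3 (within the scatter). Compound 3 is therefore estimated at 1400 nM, expected between 500 nM and 4000 nM.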

Compound 3, half-maximal cytotoxic concentration: 32000 nM
For compound 3 the middle estimate is 23-fold (1.36 log units) below the measured one; measured number outside the range, above it.
By their numbers in this assay, from the lowest: compound 1; then compound 3; then compound 2.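

The aromatic nitrogen of the shared core is a position to which this assay responds: hydrogen in place of methyl gives a 23-fold higher number from compound 1 to compound 3 (1.36 log units; beyond the scatter) and so the amide-side chain is not the only place that moves this read-out. Of this pair, compound 1, with the methyl, shows the higher toxicity in this test. Nothing in hand accounts for this step.

Open, on these data alone, is whether an ethyl group or a longer chain on that nitrogen would sit nearer compound 1 or compound 3. Also open, as far as these compounds go, is whether the same change carries over when piperidin-1-yl replaces 4-phenylpiperazin-1-yl.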